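From compound 3 to compound 4: replacing a ring

The source may hold more compounds than are shown below. What is called first, only, known or untested is meant among the compounds shown, and "the series" means these compounds.

Measured in a functional assay on B16-F10 cells (Mus musculus) for antiproliferative activity, read by CCK-8 assay, with a stated time of 48 h; a higher number here means a weaker inhibitor, a lower number a stronger inhibitor:
- Compound 1 `COc1ccc(/C=C\c2cc(OC)c(OC)c(OC)c2)cc1OCc1ccc(C=O)cc1`: 4200 nM
- Compound 2 `COc1ccc(/C=C\c2cc(OC)c(OC)c(OC)c2)cc1OCc1ccc(CN2C[C@H](O)C[C@@H]2C(=O)O)cc1`: > 10000 nM (a limit)
- Compound 3 `COc1ccc(/C=C\c2cc(OC)c(OC)c(OC)c2)cc1OCc1ccc(CN2CCCC[C@@H]2C(=O)O)cc1`: > 10000 nM (a limit)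

The value of compound 3 is a limit and not a number. Compound 3 stands at the limit of > 10000 nM in this assay, at which 2 of the 3 values shown sit, and compound 2 stands there too.

Compound 4 `COc1ccc(/C=C\c2cc(OC)c(OC)c(OC)c2)cc1OCc1ccc(CN[C@H](C(=O)O)[C@H](C)O)cc1` carries (1-carboxy-2-hydroxypropyl)amino in place of 2-carboxypiperidin-1-yl, on a saturated chain carbon bound to an aromatic carbon: (1-carboxy-2-hydroxypropyl)amino in place of 2-carboxypiperidin-1-yl on a saturated chain carbon bound to an aromatic carbon.

Among the compounds with values here, two measured steps bear on this change, as both put a carboxy-bearing group in place of formyl: an at least 2.3-fold higher number from compound 1 to compound 2 (0.37 log units; beyond the scatter) and an at least 2.3-fold higher number from compound 1 to compound 3 (0.37 log units; beyond the scatter). Both went towards weaker inhibition. The third step, a step that the two limits leave unreadable from compound 2 to compound 3, cannot be sized. Compound 4 also carries a carboxy group, so it is expected to stay near the limit, quite possibly reported only as one. The estimated step that the limit leaves unreadable from compound 3 to compound 4 is expected to lie within the scatter. For compound 4 the estimated value is 12000 nM, with an expected range from 5000 nM to 30000 nM.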

Compound 4, half-maximal inhibitory concentration: > 10000 nM
Compound 4: only a limit was reported (the forecaster's own chance of this, stated with the estimate: 75%); the middle value lies beyond the limit too.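

In this assay compound 4 gives > 10000 nM, which is a limit and not a number. Swapping the ring of 2-carboxypiperidin-1-yl for the ring-free (1-carboxy-2-hydroxypropyl)amino therefore brings no measurable value back, and the comparison with the formyl group shows an at least 2.3-fold higher number from compound 1 to compound 4 (0.37 log units; beyond the scatter). The steps among compound 2, compound 3 and compound 4 cannot be read, as both ends of each are limits, so ring and open-chain carboxy groups now end up in the same place: the limit of > 10000 nM in this assay, at which 3 of the 4 values shown sit.

As far as these compounds go, how far past the limit compound 2, compound 3 and compound 4 lie remains unknown, so these three cannot be ranked. A methyl ester in place of the carboxylic acid, or a simple amine without the acid, would test whether the carboxylic acid itself goes with this loss.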